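Solubility notes on the methyl sulfonyl analogue

The source may hold more compounds than are shown below. What is called first, only, known or untested is meant among the compounds shown, and "the series" means these compounds.

Compound 3 `COc1ccc(S(=O)(=O)N2CCN(c3ccc(OC[C@@]4(C)Cn5cc([N+](=O)[O-])nc5O4)cc3)CC2)cc1` stands at the floor of the series in a physicochemical assay for solubility, read by HPLC, with a stated time of 4 h, at pH 7; on this read-out lower numbers stand for lower solubility and higher numbers for higher solubility: compound 3 gives < 1 ug/mL, a limit rather than a number. Compound 1 `C[C@]1(COc2ccc(N3CCN(S(=O)(=O)c4ccc(F)cc4)CC3)cc2)Cn2cc([N+](=O)[O-])nc2O1` gives 8.33 ug/mL. Compound 2 `C[C@]1(COc2ccc(N3CCN(S(=O)(=O)c4ccc(C(F)(F)F)cc4)CC3)cc2)Cn2cc([N+](=O)[O-])nc2O1` gives < 1 ug/mL, again a limit. The steps of an at least 8.3-fold lower number from compound 1 to compound 2 (0.92 log units; beyond the scatter) and an at least 8.3-fold lower number from compound 1 to compound 3 (0.92 log units; beyond the scatter) both run downward beyond the scatter; the step that the two limits leave unreadable from compound 2 to compound 3 cannot be sized, which is due to the limit of < 1 ug/mL in this assay, at which 2 of the 3 values shown sit. Compound 4 `Cc1ccc(S(=O)(=O)N2CCN(c3ccc(OC[C@@]4(C)Cn5cc([N+](=O)[O-])nc5O4)cc3)CC2)cc1` differs from compound 3 by methyl in place of methoxy on an aromatic carbon. Among the compounds with values here, no measured step covers methyl; the two limits at the low end weigh against a rise. Compound 4 is therefore expected near the limit, at 0.8 ug/mL, between 0.3 ug/mL and 3 ug/mL. The step that the limit leaves unreadable from compound 3 to compound 4 is expected to stay within the scatter.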

Compound 4, solubility: < 1 ug/mL
Compound 4 ended at the assay's limit; the forecaster's own chance of this, stated with the estimate: 65%; the middle value is on the limit's open side.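

With methyl, a third group in place of fluoro on this aromatic carbon, para to a large group, gives a downward result in this assay: an at least 8.3-fold lower number from compound 1 to compound 4 (0.92 log units; beyond the scatter). Among the compounds shown, compound 1 with fluoro is now the only one with a readable number, against trifluoromethyl in compound 2, methoxy in compound 3 and methyl in compound 4. The steps among these last three cannot be read, due to this: the limit of < 1 ug/mL in this assay, at which 3 of the 4 values shown sit.

From the compounds shown here alone, how far apart compound 2, compound 3 and compound 4 truly lie stays open. So does whether an amine or a carboxylic acid on this aromatic carbon would give a readable number.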